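Swapping the carbonyl-bound ring for a pyridine in a benzimidazole series

A few compounds are considered here, and "the series" means these few. Any claim that something is new, unique, unknown or untested is made for them only; others in the source may bear on it.

Measured so far:
Compound 1 `Cc1ccc(-c2nn(-c3ccccc3)cc2-c2nc3ccccc3n2C(=O)c2ccccc2C)cc1` gives 176000 nM.
Compound 2 `Cc1ccccc1C(=O)n1c(-c2cn(-c3ccccc3)nc2-c2ccc(F)cc2)nc2ccccc21` gives 189000 nM.
Compound 3 `Cc1cncc(C(=O)n2c(-c3cn(-c4ccccc4)nc3-c3ccc(F)cc3)nc3ccccc32)c1` gives 119000 nM.

These three compounds share one core and were tested in an ADME assay on HEK-293T cells (Homo sapiens) for cytotoxicity, read by MTT assay, with a stated time of 24 h; on this read-out higher numbers stand for lower toxicity in this test and lower numbers for higher toxicity in this test. Compound 2 gives the highest of the three numbers, yet the two steps that lead to it and away from it are a 1.1-fold higher number from compound 1 to compound 2 (0.03 log units; within the scatter) and a 1.6-fold lower number from compound 2 to compound 3 (0.20 log units; within the scatter), so on these numbers the three compounds cannot be told apart.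

Compound 4 `O=C(c1ccncc1)n1c(-c2cn(-c3ccccc3)nc2-c2ccc(F)cc2)nc2ccccc21` is the next compound. Its change from compound 2 is pyridin-4-yl in place of 2-methylphenyl on a carbonyl carbon. Among the compounds with values here, the one measured step that resembles it is the one from compound 2 to compound 3, where a pyridine ring also took the place of the 2-methylphenyl group on the carbonyl carbon; that step was a 1.6-fold lower number from compound 2 to compound 3 (0.20 log units; within the scatter). The step from compound 1 to compound 2 concerns a different part of the molecule and says little here.

Compound 4 is therefore expected to sit close to compound 2, with a step of a 1.3-fold lower number from compound 2 to compound 4 (0.10 log units; within the scatter), which is nothing beyond the scatter. The estimate for compound 4 is 150000 nM, with a range from 80000 nM to 280000 nM.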

Compound 4, half-maximal cytotoxic concentration: 151000 nM
For compound 4 the middle estimate is 1.0-fold (0.00 log units) below the measured one; the range from low to high includes it.
By their numbers in this assay, from the lowest: compounds 3, 4, 1 and 2 (each within the scatter of the next).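

In this assay, a second pyridine on the carbonyl carbon gives the same picture as the first: pyridin-4-yl in place of 2-methylphenyl amounts to a 1.3-fold lower number from compound 2 to compound 4 (0.10 log units; within the scatter) and so cannot be told apart from the group it replaces. The new compound also allows a direct comparison of the two pyridines, and pyridin-4-yl in place of 5-methylpyridin-3-yl amounts to a 1.3-fold higher number from compound 3 to compound 4 (0.10 log units; within the scatter) and so shows no readable difference between them either. All three rings on this carbonyl carbon therefore give numbers that lie within the scatter of one another, and no measured evidence is available to explain this result.

Going by these compounds, all three groups at this position are six-membered aromatic rings, so it remains open whether a saturated ring such as piperidine, an open-chain amine or a longer alkyl chain on the carbonyl carbon would leave the number just as unchanged. On these data alone, the aromatic carbon carrying fluoro in compound 4 is equally open, since only fluoro and methyl appear there and a carboxylic acid at that spot could give a different result.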